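Replacing 4,4-difluoropiperidin-1-yl at the limit of clearance

The source may hold more compounds than are shown below. What is called first, only, known or untested is meant among the compounds shown, and "the series" means these compounds.

In an ADME assay on microsomes from liver (Homo sapiens) for metabolic stability, read by LC-MS, with a stated time of 40 min, tested at 0.5 uM (a higher number here means faster removal of the compound, a lower number slower removal), compound 1 (`O=C(Nc1cccc(S(=O)(=O)C2CCCC2)c1)c1cccnc1N1CCC(F)(F)CC1`) gives > 399 mL.min-1.g-1 as a limit, not a number. Compound 1 thus stands at the top of the range shown (the limit of > 399 mL.min-1.g-1 in this assay, at which 2 of the 3 values shown sit). Compound 4 (`O=C(Nc1cccc(S(=O)(=O)C2CCCC2)c1)c1cccnc1N1CCC2(CC1)CC2`) differs from compound 1 by a single exchange (a group of 8 heavy atoms (7 carbon, 1 nitrogen; one three-membered non-aromatic ring of carbon only, one six-membered non-aromatic ring with 1 hetero atom) in place of a group of 8 heavy atoms (5 carbon, 1 nitrogen, 2 fluorine; one six-membered non-aromatic ring with 1 hetero atom), on an aromatic carbon) on an aromatic carbon. Compound 3 (`CC(C)(CO)Nc1ccc(C(=O)Nc2cccc(S(=O)(=O)NC3CCCC3)n2)c(N2CCC3(CC2)CC3)c1`), which holds the entering group, gives > 399 mL.min-1.g-1 as a limit too. Compound 2 (`CC(C)(C)NS(=O)(=O)c1cccc(NC(=O)c2ncc(NS(C)(=O)=O)nc2N2CCC3(CC2)CC3)n1`) holds that group as well and goes against this, reading 127 mL.min-1.g-1 as a true number. Within the data shown here, no measured step isolates the exchange, so in this assay no shift beyond the scatter is expected, and any shift should be towards slower removal. The expected step is small (an at least 1.1-fold lower number from compound 1 to compound 4 (0.05 log units; that floor lies within the scatter)) on this reading. Compound 4 is expected at 350 mL.min-1.g-1 (estimated range 160 mL.min-1.g-1 to 399 mL.min-1.g-1).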

Compound 4, intrinsic clearance in microsomes: > 399 mL.min-1.g-1
Compound 4 gave a limit, no number; the forecaster's own chance of this, stated with the estimate: 60%; middle value at least 1.1-fold (0.05 log units) from the limit.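

Compound 1 and compound 4 both give only a limit, so no step between them can be read in this assay, because both sit at the same limit: the limit of > 399 mL.min-1.g-1 in this assay, at which 3 of the 4 values shown sit.

On these data alone, whether the exchange of 4,4-difluoropiperidin-1-yl changes intrinsic clearance in microsomes at all, and in which direction, stays open.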